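From Compound 3 to Compound 4, at the Assay Limit

The compounds below may be only part of what the source reports. "The series", "measured", "known", "first", "only" and "open" are said of these compounds alone.

Measured in a physicochemical assay for solubility, with a stated time of 24 h, at pH 4.5 (a higher number here means a more soluble compound, a lower number a less soluble compound), all values being limits:
- compound 1 `O=C(NC[C@@H]1[C@H]2CN(C(=O)OCc3cc(Cl)cc(Cl)c3)C[C@@H]12)c1ccc2[nH]c(=O)oc2c1`: < 1 ug/mL
- compound 2 `O=C(NC[C@@H]1[C@H]2CN(C(=O)C3CC3c3cc(Cl)cc(Cl)c3)C[C@@H]12)c1ccc2[nH]c(=O)oc2c1`: < 1 ug/mL
- compound 3 `O=C(NC[C@@H]1[C@H]2CN(C(=O)NCc3cc(Cl)cc(Cl)c3)C[C@@H]12)c1ccc2[nH]c(=O)oc2c1`: < 1 ug/mL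

Compound 3 stands at < 1 ug/mL, which is a limit of the assay and not a number. The same holds for the other two compounds, so the series offers (the limit of < 1 ug/mL in this assay, at which 3 of the 3 values shown sit).

Compound 4 `CC(OC(=O)N1C[C@@H]2[C@@H](CNC(=O)c3ccc4[nH]c(=O)oc4c3)[C@@H]2C1)c1cc(Cl)cc(Cl)c1` differs from compound 3 on a carbonyl carbon, where (3,5-dichlorobenzyl)amino leaves: a group of 11 heavy atoms (8 carbon, 1 oxygen, 2 chlorine; one six-membered aromatic ring of carbon only) in place of a group of 10 heavy atoms (7 carbon, 1 nitrogen, 2 chlorine; one six-membered aromatic ring of carbon only), on a carbonyl carbon.

Among the measured compounds shown here, three measured steps bear on this change, and none gives a size. There is a step that the two limits leave unreadable from compound 1 to compound 3, there is a step that the two limits leave unreadable from compound 2 to compound 3, and there is a step that the two limits leave unreadable from compound 1 to compound 2. These steps give no basis for expecting a move in either direction in this assay. The estimated step is a step that the limit leaves unreadable from compound 3 to compound 4, and no step beyond the usual scatter is expected. For compound 4 the estimated value is 0.6 ug/mL, with an expected range of 0.2 ug/mL to 2 ug/mL.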

Compound 4, solubility: < 1 ug/mL
Compound 4 was reported as a limit; the forecaster's own chance of this, stated with the estimate: 85%; the middle value lies beyond the limit too.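

In this assay compound 4 gives < 1 ug/mL, a limit of the assay and not a number. No step from compound 1, compound 2 or compound 3 to compound 4 can be read: the limit of < 1 ug/mL in this assay, at which 4 of the 4 values shown sit.

The compounds shown leave open how soluble any of the four actually is, and whether the changes among them alter solubility at all.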